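Replacing a Piperidine Amide with a Morpholine Amide

A few compounds are considered here, and "the series" means these few. Any claim that something is new, unique, unknown or untested is made for them only; others in the source may bear on it.

Compound 1 `Cc1cccc(NC(=O)/C(C#N)=C/c2cc(O)c(O)c([N+](=O)[O-])c2)c1` gives 12.5 ug/mL in a functional assay on KB cells (Homo sapiens) for antiproliferative activity, read by MTT assay; a higher number here means a weaker inhibitor, a lower number a stronger inhibitor.
Compound 2 `N#C/C(=C\c1cc(O)c(O)c([N+](=O)[O-])c1)C(=O)Nc1cccc(Cl)c1` gives 72.7 ug/mL in this assay.
Compound 3 `N#C/C(=C\c1cc(O)c(O)c([N+](=O)[O-])c1)C(=O)N1CCCCC1` reaches only a limit of this assay, > 100 ug/mL.

Compound 3 therefore stands at the weak end of what has been measured: its result is an assay limit, (the limit of > 100 ug/mL in this assay, at which 1 of the 3 values shown sits), rather than a number. The steps leading to it are an at least 8.0-fold higher number from compound 1 to compound 3 (0.90 log units; beyond the scatter) and an at least 1.3-fold higher number from compound 2 to compound 3 (0.13 log units; that floor lies within the scatter). Compound 4 `N#C/C(=C\c1cc(O)c(O)c([N+](=O)[O-])c1)C(=O)N1CCOCC1` differs from compound 3 in one place: morpholin-4-yl in place of piperidin-1-yl on a carbonyl carbon. Among the measured compounds shown here, no measured step swaps one saturated ring for another at this position; the two steps that touch the carbonyl substituent both exchange an arylamino group for piperidin-1-yl, so they give only indirect guidance. The nearest comparison, between compound 2 and compound 3, lies within the scatter. Compound 4 is expected to give 150 ug/mL, ranging from 60 ug/mL to 400 ug/mL. The step that the limit leaves unreadable from compound 3 to compound 4 is expected to remain within the scatter, with a good chance that only a limit is reported again.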

Compound 4, half-maximal inhibitory concentration: > 100 ug/mL
Compound 4: a limit, no number; the forecaster's own chance of this, stated with the estimate: 70%; the middle value lies beyond the limit too.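

Compound 4, like compound 3, stops at a limit of this assay, so the exchange of piperidin-1-yl for morpholin-4-yl cannot be read in either direction: the limit of > 100 ug/mL in this assay, at which 2 of the 4 values shown sit.

What is new is that a second saturated ring on the carbonyl carbon, this one holding an oxygen, also gives no number. Against the arylamino amides, the change gives an at least 8.0-fold higher number from compound 1 to compound 4 (0.90 log units; beyond the scatter), and it gives an at least 1.3-fold higher number from compound 2 to compound 4 (0.13 log units; that floor lies within the scatter). Both saturated rings thus lie clearly on the weak side of compound 1, while neither can be separated from compound 2.

As far as these compounds go, how far compound 3 and compound 4 lie past the limit stays open. So does whether a piperazine ring or an open-chain dimethylamino group on the same carbonyl carbon would give a number in this assay.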